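The source may hold more compounds than are shown below. What is called first, only, known or untested is meant among the compounds shown, and "the series" means these compounds.

In a functional assay on MDA-MB-231 cells (Homo sapiens) for antiproliferative activity, read by MTT assay, with a stated time of 48 h (on this read-out higher numbers stand for weaker inhibition and lower numbers for stronger inhibition), compound 1 (`COc1ccc(N(C)c2ccnc(Cl)n2)cc1OCCBr`) gives 6620 nM and compound 2 (`COc1ccc(N(C)c2ccnc(Cl)n2)cc1OCCC[Se]C#N`) holds the lower of the two numbers with 1490 nM so far. Compound 3 (`COc1ccc(N(C)c2ccnc(Cl)n2)cc1OCCCCC[Se]C#N`) differs from compound 2 by a group of 5 heavy atoms (3 carbon, 1 nitrogen, 1 selenium; no ring) in place of a group of 3 heavy atoms (1 carbon, 1 nitrogen, 1 selenium; no ring), on a saturated chain carbon, three bonds along the chain from an oxygen on an aromatic ring and has not yet been measured. For the measured compounds named here, the only measured step to go on is a 4.4-fold lower number from compound 1 to compound 2 (0.65 log units; beyond the scatter) which replaced one bromine atom and is only a loose guide to this change, so no step beyond the scatter is expected in this assay here. The estimated step is a 1.4-fold lower number from compound 2 to compound 3 (0.13 log units; within the scatter) in size. Compound 3 is expected at 1100 nM with an estimated range of 400 nM to 3000 nM in this test.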

Compound 3, half-maximal inhibitory concentration: > 10000 nM
Compound 3: only a limit was reported; the forecaster's own chance of this, stated with the estimate: 3%; middle value at least 9.0-fold (0.95 log units) away from the limit.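

In this assay compound 3 gives only a limit, not a number: the limit of > 10000 nM in this assay, at which 1 of the 3 values shown sits. Even so, the larger group gives an at least 6.7-fold higher number from compound 2 to compound 3 (0.82 log units; beyond the scatter), so at this chain position the selenium-bearing group does not tolerate every size, and the improvement of a 4.4-fold lower number from compound 1 to compound 2 (0.65 log units; beyond the scatter) does not carry over. Against the bromine compound, the result is an at least 1.5-fold higher number from compound 1 to compound 3 (0.17 log units; that floor lies within the scatter), a floor within the scatter that still leaves compound 3 without a true value.

Going by these compounds, how a chain of intermediate length would behave remains open. So does the effect of an amine or a carboxylic acid in place of this group.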